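Swapping a nitro group's ring position on two shared cores

The source may report more compounds than this note shows. Statements on the series, on what has been measured and on what is new or still open speak of the compounds shown alone.

Compound 1 `CN(C)c1ccc(/C=C2\CCC/C(=C\c3cccc([N+](=O)[O-])c3)C2=O)cc1` and compound 2 `COc1cc(/C=C2\CCC/C(=C\c3cccc([N+](=O)[O-])c3)C2=O)cc(OC)c1OC` share a central ring flanked by two arylidene arms; how their two cores differ is not broken down here. In a functional assay on HSC-4 cells (Homo sapiens) for cytotoxicity, with a stated time of 24 h (a higher number here means that more compound is tolerated, a lower number that less compound is tolerated), compound 1 gives 71000 nM. In this assay compound 2 gives 92000 nM, and these two values lie within the scatter of each other. Compound 3 `CN(C)c1ccc(/C=C2\CCC/C(=C\c3ccc([N+](=O)[O-])cc3)C2=O)cc1` is compound 1 with 4-nitrophenyl in place of 3-nitrophenyl on a double-bonded chain carbon bound to a double-bonded ring carbon. For compound 3 this assay reports only a limit, > 400000 nM, not a number. That change gives an at least 5.6-fold higher number from compound 1 to compound 3 (0.75 log units; beyond the scatter), with the end sitting at the limit of > 400000 nM in this assay, at which 1 of the 3 values shown sits. Compound 4 `COc1cc(/C=C2\CCC/C(=C\c3ccc([N+](=O)[O-])cc3)C2=O)cc(OC)c1OC`, not yet measured, is compound 2 with the same change, (4-nitrophenyl in place of 3-nitrophenyl on a double-bonded chain carbon bound to a double-bonded ring carbon), at the same place. Because compound 1 moved to compound 3 by an at least 5.6-fold higher number from compound 1 to compound 3 (0.75 log units; beyond the scatter), a step of similar size is expected from compound 2 to compound 4, namely a 5.4-fold higher number from compound 2 to compound 4 (0.74 log units; beyond the scatter). Compound 4 is therefore estimated to give 500000 nM in this assay, with an expected range from 200000 nM to 1500000 nM, and a real chance that only a limit is reported.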

Compound 4, half-maximal cytotoxic concentration: 1500 nM
Beside the measured number, compound 4's estimate is 330-fold (2.52 log units) above it, and the stated range ends above it.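

Placing 4-nitrophenyl where 3-nitrophenyl stood gives a 61-fold lower number from compound 2 to compound 4 (1.79 log units; beyond the scatter) in this assay, so far less of compound 4 is tolerated, whereas the same change on the core of compound 1 moved the number the other way. Set side by side, the two steps differ in direction and in size, so this change cannot be carried from one core to the other in this pair: the same change on two cores in this assay, an at least 5.6-fold higher number (0.75 log units; beyond the scatter) from compound 1 to compound 3 and a 61-fold lower number (1.79 log units; beyond the scatter) from compound 2 to compound 4, at least 340-fold (2.53 log units) apart, beyond the scatter of two such steps. The result covers only these two cores, does not show what about them makes the outcomes part ways, and has a limit rather than a number at one end of the comparison: the limit of > 400000 nM in this assay, at which 1 of the 4 values shown sits.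

The compounds shown leave open whether the same split would appear with a nitrile or a carboxylic acid in place of the nitro group, or with a hydroxy group in place of the methoxy groups. As far as these compounds go, whether other cores would follow compound 1 or compound 2 also stays open.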